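A Single Halogen Swap on a Shared Aromatic Ring

The source may report more compounds than this note shows. Statements on the series, on what has been measured and on what is new or still open speak of the compounds shown alone.

Two measured compounds share one core and differ at just one aromatic carbon. Compound 1 `COc1ccc(-c2cc(-c3ccccc3)n[nH]2)cc1` carries a hydrogen there, and in a functional assay on NCI-H460 cells (Homo sapiens) for inhibition, read by MTT assay, with a stated time of 48 h (a lower number here means a stronger inhibitor of growth, a higher number a weaker inhibitor of growth), compound 1 gives 10400 nM. Compound 2 `COc1ccc(-c2cc(-c3ccc(Cl)cc3)n[nH]2)cc1` carries a chloro group at that carbon, and in this assay compound 2 gives 11600 nM. The step between them, a 1.1-fold higher number from compound 1 to compound 2 (0.05 log units; within the scatter), is within the scatter. Within the data shown here, compound 2 thus has the highest number of the two, but its only neighbour, compound 1, sits within the scatter of it, so no real order between the two can be claimed.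

Compound 3 `COc1ccc(-c2cc(-c3ccc(Br)cc3)n[nH]2)cc1` is the next member: bromo in place of chloro on an aromatic carbon. Among the measured compounds shown here, the only measured step that bears on this change is the earlier substitution at the same carbon, a 1.1-fold higher number from compound 1 to compound 2 (0.05 log units; within the scatter), which did not move the number beyond the scatter. Exchanging one halogen for another at the same place therefore gives no ground to expect a shift in this assay beyond the scatter, in either direction. Compound 3 is expected to give about 11000 nM in this assay, with a range from 5000 nM to 25000 nM. The expected shift is then a 1.1-fold lower number from compound 2 to compound 3 (0.02 log units; within the scatter).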

Compound 3, concentration for 50% growth inhibition: 27100 nM
Compound 3: middle estimate off by 2.5-fold (0.39 log units), on the low side; measured number outside the range, above it.
By their numbers in this assay, from the lowest: compounds 1 and 2 (each within the scatter of the next); then compound 3.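

In this assay, this carbon, para to a large group, turns out not to be indifferent to what it carries: the change from chloro to bromo gives a 2.3-fold higher number from compound 2 to compound 3 (0.37 log units; beyond the scatter), whereas the earlier change from hydrogen to chloro stayed within the scatter. The comparison with the unsubstituted compound agrees, with a 2.6-fold higher number from compound 1 to compound 3 (0.42 log units; beyond the scatter), so bromo is the only substituent among these three compounds that separates from the others, and it does so towards weaker inhibition of growth, though only modestly. The two halogens therefore cannot be treated as interchangeable at this carbon, and nothing available here explains why they differ.

The three compounds cover only hydrogen, chloro and bromo at one carbon, so they do not establish whether the number would keep rising with iodo or whether this is a steady trend at all. They also leave open whether a different kind of group at the same carbon, such as an amine or a carboxylic acid, would bring the number down and give a stronger inhibitor of growth rather than a weaker one.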